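This account rests on a few compounds, and the source may have more. Where it says the series, first, only, none or still open, it means among the compounds named here.

Measured so far in a functional assay on PC-3 cells (Homo sapiens) for inhibition, read by MTT assay, with a stated time of 48 h; a higher number here means a weaker inhibitor, a lower number a stronger inhibitor:
compound 1, `COc1ccc(-n2c(SCC(=O)c3ccccc3)nnc2-c2cc(OC)c(OC)c(OC)c2)cc1`: a limit of the assay, > 60000 nM
compound 2, `COc1ccc(C(=O)CSc2nnc(-c3cc(OC)c(OC)c(OC)c3)n2-c2ccc(OC)cc2)cc1`: a limit of the assay, > 60000 nM
compound 3, `COc1cc(-c2nnc(SCc3ccccc3)n2-c2ccc(N(C)C)cc2)cc(OC)c1OC`: in this assay compound 3 gives 55800 nM.

Compound 3 is the only one of the three with a number in this assay. For compound 1 the value is a limit and not a number. For compound 2 the value is likewise a limit and not a number. The change from compound 1 to compound 2 is methoxy in place of hydrogen on an aromatic carbon; its step, a step that the two limits leave unreadable from compound 1 to compound 2, cannot be read because of the limit of > 60000 nM in this assay, at which 2 of the 3 values shown sit.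

Compound 4, `COc1ccc(CSc2nnc(-c3cc(OC)c(OC)c(OC)c3)n2-c2ccc(N(C)C)cc2)cc1`, is not yet measured in this assay. It differs from compound 3 by methoxy in place of hydrogen on an aromatic carbon. The place is the same, word for word, as in the change from compound 1 to compound 2, so this is the same change, made twice among the compounds shown. The difference between the core of compound 3 and the core of compound 1 is not broken down here.

The earlier step being unreadable, the expectation for compound 4 rests on compound 3 alone, which gives 55800 nM. The step is expected to be a 1.0-fold lower number from compound 3 to compound 4 (0.01 log units; within the scatter), that is, within the scatter. Compound 4 is estimated at 55000 nM, expected between 25000 nM and 120000 nM, with a real chance that only a limit is reported.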

Compound 4, half-maximal inhibitory concentration: > 60000 nM
Compound 4 gave a limit, no number; the forecaster's own chance of this, stated with the estimate: 45%; middle value at least 1.0-fold (0.03 log units) from the limit.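

In this assay, the change of benzyl to 4-methoxybenzyl on the core of compound 3 reads as an at least 1.0-fold higher number from compound 3 to compound 4 (0.03 log units; that floor lies within the scatter), a floor and not a measured size. Neither compound 2 nor compound 4, the two compounds that carry the added methoxy, gives a number here, which is all the series shows about this change. The step on the core of compound 1 cannot be read, and whether the change carries from one core to the other stays unanswered, neither supported nor contradicted, because both readings run into the same bound: the limit of > 60000 nM in this assay, at which 3 of the 4 values shown sit.

Open, going by these compounds, is whether any other group on that aromatic carbon, para to a large group, such as an amine or a carboxylic acid, would give a number clear of this limit in this assay. Also open, on these data alone, is what size the methoxy step has on a core whose values lie well inside the range of this assay.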